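Moving the chlorine: 2-chlorophenyl to 4-chlorophenyl

A few compounds are considered here, and "the series" means these few. Any claim that something is new, unique, unknown or untested is made for them only; others in the source may bear on it.

In an ADME assay on HUVEC cells (Homo sapiens) for cytotoxicity, read by MTT assay, with a stated time of 24 h (a lower number here means that less compound is tolerated, a higher number that more compound is tolerated), compound 1 (`O=[N+]([O-])c1ccc(/C=C/c2nnc(-c3ccc4c(c3)OCCO4)o2)cc1`) gives 299000 nM and compound 2 (`Fc1ccc(/C=C/c2nnc(-c3ccc4c(c3)OCCO4)o2)cc1`) gives 325000 nM while compound 3 (`Clc1ccccc1/C=C/c1nnc(-c2ccc3c(c2)OCCO3)o1`) gives 368000 nM so compound 3 stands level with the other two, all within the usual scatter. Compound 4 (`Clc1ccc(/C=C/c2nnc(-c3ccc4c(c3)OCCO4)o2)cc1`) has 4-chlorophenyl in place of 2-chlorophenyl on a double-bonded chain carbon bound to a double-bonded chain carbon. Going by the values given here, two measured steps bear on this. Fluoro in place of nitro shows a 1.1-fold higher number from compound 1 to compound 2 (0.04 log units; within the scatter) and 2-chlorophenyl in place of 4-fluorophenyl shows a 1.1-fold higher number from compound 2 to compound 3 (0.05 log units; within the scatter) so neither exceeds the scatter. No step beyond the scatter is therefore expected in this assay and the estimated step is a 1.1-fold lower number from compound 3 to compound 4 (0.03 log units; within the scatter) at most a small one. Compound 4 is estimated at 340000 nM with an expected range from 230000 nM to 500000 nM in this test.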

Compound 4, half-maximal cytotoxic concentration: 312000 nM
Compound 4: middle estimate off by 1.1-fold (0.04 log units), on the high side; low and high end bracket the measured number.
By their numbers in this assay, from the lowest: compounds 1, 4, 2 and 3 (each within the scatter of the next).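

In this assay, 4-chlorophenyl in place of 2-chlorophenyl on a double-bonded chain carbon bound to a double-bonded chain carbon reads level (a 1.2-fold lower number from compound 3 to compound 4 (0.07 log units; within the scatter)), so joining the same atoms differently here shows no effect beyond the scatter. Chloro on the aromatic carbon also reads level with fluoro (a 1.0-fold lower number from compound 2 to compound 4 (0.02 log units; within the scatter)) and with nitro (a 1.0-fold higher number from compound 1 to compound 4 (0.02 log units; within the scatter)). Nothing measured here offers an explanation for this flat picture. On these data alone, whether an amine or a carboxylic acid in place of the chlorine would read level too remains open.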